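From Pyrrolidin-1-yl to Hydroxy: an Expected Step

The compounds below may be only part of what the source reports. "The series", "measured", "known", "first", "only" and "open" are said of these compounds alone.

Of the compounds shown here, two have been tested in a functional assay on HT-29 cells (Homo sapiens) for antiproliferative activity, read by MTT assay, with a stated time of 24 h; a higher number here means a weaker inhibitor, a lower number a stronger inhibitor. Compound 1 `COc1cc(OC)c(OC)cc1/C=C/C(=O)c1ccc(OC)c2c1OC(C)(C)C=C2` gives only a limit in this assay, > 10000 nM. For the measured compounds named here, compound 2 `COc1ccc(C(=O)/C=C/c2ccc(N3CCCC3)cc2)c2c1C=CC(C)(C)O2` gives 8360 nM in this assay, the only actual number so far. Compound 3 `COc1ccc(C(=O)/C=C/c2ccc(O)cc2)c2c1C=CC(C)(C)O2` has not been measured; it differs from compound 2 by hydroxy in place of pyrrolidin-1-yl on an aromatic carbon. Going by the values given here, no measured step between compounds differing in one place is available, so the expectation rests on compound 2 alone. Because compound 2 gives 8360 nM, a small step toward a weaker inhibitor, or none beyond the scatter, is expected, a 1.4-fold higher number from compound 2 to compound 3 (0.16 log units; within the scatter). Compound 3 is therefore estimated at 12000 nM, between 4000 nM and 35000 nM.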

Compound 3, half-maximal inhibitory concentration: > 10000 nM
Compound 3 gave a limit, no number; the forecaster's own chance of this, stated with the estimate: 50%; the middle value is on the limit's open side.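

Replacing pyrrolidin-1-yl with hydroxy on an aromatic carbon para to a large group gives, in this assay, an at least 1.1-fold higher number from compound 2 to compound 3 (0.07 log units; that floor lies within the scatter). For the compounds shown here, this is the first step read at this position, and it shows that hydroxy does not yield a measurable number in this assay. The step has a floor but no upper end, and how far compound 3 lies from compound 2 cannot be read: the limit of > 10000 nM in this assay, at which 2 of the 3 values shown sit.

As far as these compounds go, what an open-chain amine such as dimethylamino or a carboxylic acid would give at this position remains open. So does whether any group here could give a clearly stronger inhibitor than compound 2.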